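A few compounds are considered here, and "the series" means these few. Any claim that something is new, unique, unknown or untested is made for them only; others in the source may bear on it.

For the measured compounds named here, compound 1 `CN(C(=O)NC(=O)c1ccc(F)c(F)c1)c1nc(C(F)(F)F)c(C(=O)N/N=C/c2ccc(C(F)(F)F)cc2)s1` is the one member of this small set that gives a number in a functional assay on A549 cells (Homo sapiens) for inhibition, read by MTT assay, with a stated time of 72 h (on this read-out lower numbers stand for stronger inhibition and higher numbers for weaker inhibition), where compound 1 gives 6.07 ug/mL. Compound 2 `CNc1nc(C)c(C(=O)N/N=C/c2ccccc2C(F)(F)F)s1` reaches only a limit of > 100 ug/mL in this assay. Compound 3 `CNc1nc(C)c(C(=O)N/N=C/c2cccc(C(F)(F)F)c2)s1` likewise stops at a limit of > 100 ug/mL. Two of the three results therefore sit at the limit of > 100 ug/mL in this assay, at which 2 of the 3 values shown sit, and compound 1 stands alone with a measured value. Compound 4 `CN(C(=O)NC(=O)c1cccc(C(F)(F)F)c1)c1nc(C(F)(F)F)c(C(=O)N/N=C/c2ccc(C(F)(F)F)cc2)s1` has not been measured; it differs from compound 1 by 3-(trifluoromethyl)phenyl in place of 3,4-difluorophenyl on a carbonyl carbon, with the shared core otherwise kept. Going by the values given here, no step between measured compounds guides this change, so the expected step from compound 1 to compound 4 is a 1.1-fold higher number from compound 1 to compound 4 (0.03 log units; within the scatter), nothing beyond the scatter in either direction. Compound 4 is accordingly estimated at 6.5 ug/mL, ranging from 2.5 ug/mL to 17 ug/mL.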

Compound 4, half-maximal inhibitory concentration: 6.2 ug/mL
Estimate against measurement, compound 4: 1.0-fold (0.02 log units) above, within the range that was stated.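

In this assay, 3-(trifluoromethyl)phenyl in place of 3,4-difluorophenyl on a carbonyl carbon gives a 1.0-fold higher number from compound 1 to compound 4 (0.01 log units; within the scatter) and so shows that this place accepts one substituted phenyl for the other, the entering group having the higher heavy-atom count, with no change beyond the scatter. No measured property shown here bears on this result. As far as these compounds go, whether a group of another kind at this place, such as an amine, a carboxylic acid or a longer chain, would keep the value stays open. Compound 2 and compound 3 differ from compound 1 in more than one place and cannot settle this.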